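The source may hold more compounds than are shown below. What is called first, only, known or untested is meant among the compounds shown, and "the series" means these compounds.

Working notes on the series.

Compound 1 `Cn1c(/C=C/C(=O)c2ccccc2O)cc(Br)c1Br` and compound 2 `Cn1c(/C=C/C(=O)c2ccc[nH]2)cc(Br)c1Br` share the methylated core; how the two cores differ is not broken down here. In a functional assay on KB403 cells (Homo sapiens) for cytotoxicity, read by MTT assay, with stated times of 6 h and 48 h (a lower number here means a stronger inhibitor, a higher number a weaker inhibitor), compound 1 gives 8320 nM, while compound 2 gives 600 nM, the lowest number of the two measured values.

Compound 3 `O=C(/C=C/c1cc(Br)c(Br)[nH]1)c1ccccc1O` differs from compound 1 by hydrogen in place of methyl on an aromatic nitrogen. For compound 3 the result is a limit of the assay, >= 100000 nM. The step of an at least 12-fold higher number from compound 1 to compound 3 (1.07 log units; beyond the scatter) is read against that limit (the limit of >= 100000 nM in this assay, at which 1 of the 3 values shown sits).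

Compound 4 `O=C(/C=C/c1cc(Br)c(Br)[nH]1)c1ccc[nH]1` is not yet measured. It differs from compound 2 by hydrogen in place of methyl on an aromatic nitrogen. The surroundings are not word for word the same as in the first pair: in the step from compound 1 to compound 3 the nitrogen sits next to the ring atom that bears a large group, in the step from compound 2 to compound 4 next to the ring atom that bears a group of 9 heavy atoms, so the two changes are the same kind of change rather than the same.

The number for compound 4 in this assay is expected to rise by a 17-fold higher number from compound 2 to compound 4 (1.22 log units; beyond the scatter), resting on compound 1 and the step of an at least 12-fold higher number from compound 1 to compound 3 (1.07 log units; beyond the scatter). Compound 4 is estimated at 10000 nM, between 2500 nM and 100000 nM.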

Compound 4, half-maximal inhibitory concentration: >= 100000 nM
Compound 4: a limit, no number (the forecaster's own chance of this, stated with the estimate: 30%); middle value at least 10-fold (1.00 log units) from the limit.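

In this assay compound 4 gives >= 100000 nM, a limit of the assay and not a number. Hydrogen in place of methyl on an aromatic nitrogen gives an at least 160-fold higher number from compound 2 to compound 4 (2.22 log units; beyond the scatter), so the direction seen on the core of compound 1 recurs on the core of compound 2, while the sizes of the two steps cannot be ranked: the same change on two cores in this assay, an at least 12-fold higher number (1.07 log units; beyond the scatter) from compound 1 to compound 3 and an at least 160-fold higher number (2.22 log units; beyond the scatter) from compound 2 to compound 4; the limit leaves it open whether they differ Compound 3 and compound 4 both end at the limit, so neither step has a true size, and two pairs establish nothing beyond these four compounds: the limit of >= 100000 nM in this assay, at which 2 of the 4 values shown sit.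

The compounds shown leave open what other groups on that aromatic nitrogen would give, such as ethyl, a longer chain or a chain ending in an amine. They also leave open whether the same step holds on a core carrying chloro groups in place of the bromo groups.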